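Bromo in place of fluoro on the shared core

The compounds below may be only part of what the source reports. "The series", "measured", "known", "first", "only" and "open" are said of these compounds alone.

Compound 3 `COc1ccc(/C=C/c2cc(OC)cc(OC)c2/C=C/C(=O)c2cc3cc(F)ccc3oc2=O)cc1` stands as the higher of the two numbers in an assay on isolated protein for inhibition of Amine oxidase [flavin-containing] A (Homo sapiens), read by fluorescence, with a stated time of 15 min (a lower number here means a stronger inhibitor, a higher number a weaker inhibitor), where compound 3 gives 44300 nM. Its nearest neighbour is compound 1 `COc1ccc(/C=C/c2cc(OC)cc(OC)c2/C=C/C(=O)c2cc3ccccc3oc2=O)cc1`, which in this assay gives 41700 nM. Compound 2 `COc1ccc(/C=C/c2cc(OC)cc(OC)c2/C=C/C(=O)c2cc3cc(Br)cc(OC)c3oc2=O)cc1` reaches only a limit in this assay, > 60000 nM. Compound 4 `COc1ccc(/C=C/c2cc(OC)cc(OC)c2/C=C/C(=O)c2cc3cc(Br)ccc3oc2=O)cc1` differs from compound 3 by bromo in place of fluoro on an aromatic carbon. Among the measured compounds shown here, the one measured step at this position, fluoro replacing hydrogen, gave a 1.1-fold higher number from compound 1 to compound 3 (0.03 log units; within the scatter), so a halogen at this carbon has so far left the number unchanged; no measured pair shows bromo against fluoro here. The step of a 1.2-fold higher number from compound 3 to compound 4 (0.07 log units; within the scatter) is therefore expected to be small, at most a modest weakening. For compound 4 the estimated value is 52000 nM, with a range from 25000 nM to 110000 nM.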

Compound 4, half-maximal inhibitory concentration: 12100 nM
Beside the measured number, compound 4's estimate is 4.3-fold (0.63 log units) above it; measured number outside the range, below it.
By their numbers in this assay, from the lowest: compound 4; then compounds 1 and 3 (each within the scatter of the next). At a limit, above all of these: compound 2.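

Bromo at this aromatic carbon moves the number where fluoro did not: it gives a 3.7-fold lower number from compound 3 to compound 4 (0.56 log units; beyond the scatter) and a 3.4-fold lower number from compound 1 to compound 4 (0.54 log units; beyond the scatter), so in this assay the change depends on which halogen is present, not on a halogen being there at all. Compound 2 stands at a limit and not at a number: the limit of > 60000 nM in this assay, at which 1 of the 4 values shown sits. With bromo kept, hydrogen in place of methoxy gives an at least 4.9-fold lower number from compound 2 to compound 4 (0.69 log units; beyond the scatter).

The gain rests on compound 4 alone. Going by these compounds, what chloro, iodo or a methyl group would give at this carbon stays open.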